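Swapping the aryl group on compound 3

The source may report more compounds than this note shows. Statements on the series, on what has been measured and on what is new or still open speak of the compounds shown alone.

Measured in a functional assay on KBVIN cells (Homo sapiens) for antiproliferative activity, read by sulforhodamine B assay, with a stated time of 3 days; on this read-out higher numbers stand for an effect only at larger amounts of compound and lower numbers for an effect already at smaller amounts:
compound 1 `CCCc1ccc(-c2cc(=O)c3c(o2)C(CC)(CC)C(=O)C(CC)=C3O)cc1`: 12.2 uM
compound 2 `CCC1=C(O)c2c(oc(-c3ccccc3F)cc2=O)C(CC)(CC)C1=O`: 3.93 uM
compound 3 `CCC1=C(O)c2c(oc(-c3ccc(C)c(C)c3)cc2=O)C(CC)(CC)C1=O`: 0.71 uM

Compound 3 stands lowest of the three at 0.71 uM. Compound 4 `CCC1=C(O)c2c(oc(-c3ccc(OC)c(Cl)c3)cc2=O)C(CC)(CC)C1=O` keeps the shared core but carries 3-chloro-4-methoxyphenyl in place of 3,4-dimethylphenyl on an aromatic carbon. All measured steps changed the aryl group at this place, and each went beyond the scatter: a 3.1-fold lower number from compound 1 to compound 2 (0.49 log units; beyond the scatter), a 5.5-fold lower number from compound 2 to compound 3 (0.74 log units; beyond the scatter) and a 17-fold lower number from compound 1 to compound 3 (1.24 log units; beyond the scatter). Within the data shown here, a real change is therefore likely, although no measured compound carries chloro or methoxy. With compound 3 already the lowest at 0.71 uM, a modest rise seems more likely than a further drop. The expected change in this assay is a 2.1-fold higher number from compound 3 to compound 4 (0.32 log units; beyond the scatter). For compound 4 the estimated value is 1.5 uM, with an expected range from 0.5 uM to 4.5 uM.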

Compound 4, concentration for half-maximal effect: 1.37 uM
For compound 4 the middle estimate is 1.1-fold (0.04 log units) above the measured one; the range from low to high includes it.
By their numbers in this assay, from the lowest: compounds 3 and 4 (each within the scatter of the next); then compound 2; then compound 1.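

In this assay, 3-chloro-4-methoxyphenyl, the only aryl group shown that carries chloro and methoxy, stays within the scatter of 3,4-dimethylphenyl (a 1.9-fold higher number from compound 3 to compound 4 (0.29 log units; within the scatter)), so this position keeps its low number with a hydrogen-bond acceptor in the aryl group. The new group also stays clearly below the two other aryl groups (a 2.9-fold lower number from compound 2 to compound 4 (0.46 log units; beyond the scatter); an 8.9-fold lower number from compound 1 to compound 4 (0.95 log units; beyond the scatter)). Nothing available explains these differences. The compounds shown leave open whether chloro or methoxy alone would give the same number, and how an amine or a carboxylic acid on this aryl ring would read.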